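This account rests on a few compounds, and the source may have more. Where it says the series, first, only, none or still open, it means among the compounds named here.

Compound 3 `Cc1nc(-c2ccccc2Cl)sc1COc1ccc2c(c1)OCC2CC(=O)O` stands lowest of the three numbers in a functional assay on CHO cells for agonist activity at Free fatty acid receptor 1 (Homo sapiens), read by FLIPR and calcium flux, tested at 100 nM; on this read-out higher numbers stand for a stronger effect at the one concentration tested and lower numbers for a weaker effect: compound 3 gives 12.4%, while compound 1 `Cc1nc(-c2cccs2)sc1COc1ccc2c(c1)OCC2CC(=O)O` gives 35.2% and compound 2 `Cc1cccc(-c2nc(C)c(COc3ccc4c(c3)OCC4CC(=O)O)s2)c1` gives 47.2%. Compound 4 `Cc1nc(-c2cccc(F)c2)sc1COc1ccc2c(c1)OCC2CC(=O)O` differs from compound 3 by 3-fluorophenyl in place of 2-chlorophenyl on an aromatic carbon. Within the data shown here, two measured steps bear on this change: the large drop a number 34.8 percentage points lower from compound 2 to compound 3 (beyond the scatter), which compound 4 undoes in part by giving up the 2-chlorophenyl, and the drop a number 22.8 percentage points lower from compound 1 to compound 3 (beyond the scatter); the rise a number 12 percentage points higher from compound 1 to compound 2 (beyond the scatter) shows a 3-methylphenyl standing above thiophen-2-yl. Compound 4 is therefore expected to move upward beyond the scatter, a step of a number 22.6 percentage points higher from compound 3 to compound 4 (beyond the scatter). Compound 4 is estimated at 35%, with a range from 18% to 55%.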

Compound 4, a percentage reported as activity, at one concentration (the size of the read-out at that concentration, not a potency): 56.9%
Beside the measured number, compound 4's estimate is 21.9 percentage points below it, outside the stated range (above it).
By their numbers in this assay, from the lowest: compound 3; then compound 1; then compounds 2 and 4 (each within the scatter of the next).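

At this position, on the ring carbon next to the ring nitrogen and the ring sulfur, 3-fluorophenyl in place of 2-chlorophenyl gives a number 44.5 percentage points higher from compound 3 to compound 4 (beyond the scatter), and in place of thiophen-2-yl it gives a number 21.7 percentage points higher from compound 1 to compound 4 (beyond the scatter). Fluoro in place of methyl gives a number 9.7 percentage points higher from compound 2 to compound 4 (within the scatter), so 3-fluorophenyl and 3-methylphenyl cannot be told apart in this assay. No measurement at hand bears on the reason for these steps.

The step from compound 3 to compound 4 changes both the halogen and its place on the phenyl ring, and the two remain unseparated. A 3-chlorophenyl or 2-fluorophenyl group would divide them.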